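Series notes: step from compound 2 to compound 4

The compounds below may be only part of what the source reports. "The series", "measured", "known", "first", "only" and "open" are said of these compounds alone.

Three members of the series have been measured in a functional assay (blood) for inhibition, with Homo sapiens as the target; a higher number here means a weaker inhibitor, a lower number a stronger inhibitor. Compound 1 `COC1(c2cc(F)cc(Sc3ccc4c(c3)CC/C4=N\OCC#N)c2)CCOCC1` gives 30 nM, and compound 3 `CO[C@]1(c2cc(F)cc(Sc3ccc(/C(C)=N/OCC#N)cc3)c2)CCO[C@@H](C)C1` gives 40 nM. Compound 2 `CN(C)/C(=N\O)c1ccc(Sc2cc(F)cc(C3CCOCC3)c2)cc1` gives 280 nM, which is the highest of the three numbers: its nearest neighbour is compound 3, whose number is lower by an amount beyond the scatter, and the gap to compound 1 is wider still. On the numbers shown, compound 2 is therefore the weakest inhibitor of the three.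

Compound 4 `C/C(=N\OCC(=O)O)c1ccc(Sc2cc(F)cc(C3CCOCC3)c2)cc1` has not yet been measured in this assay . It differs from compound 2 at one place:

a group of 8 heavy atoms (4 carbon, 1 nitrogen, 3 oxygen; no ring) in place of a group of 6 heavy atoms (3 carbon, 2 nitrogen, 1 oxygen; no ring), on an aromatic carbon

For the measured compounds named here, no pair of measured compounds differing in exactly this way is available, so the size of the step cannot be read from the data. The group that enters resembles, in its count of carbon and oxygen and in its single double bond outside aromatic rings, the groups carried by compound 1 and compound 3 more than the group that leaves; both of those compounds give lower numbers than compound 2. A step downward beyond the scatter is therefore expected, of the size a 3.1-fold lower number from compound 2 to compound 4 (0.49 log units; beyond the scatter), while a change of this kind could also leave the number near that of compound 2.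

Compound 4 is estimated at 90 nM in this assay , within a range from 25 nM to 320 nM.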

Compound 4, half-maximal inhibitory concentration: 740 nM
Beside the measured number, compound 4's estimate is 8.2-fold (0.91 log units) below it, and the stated range ends below it.
By their numbers in this assay, from the lowest: compounds 1 and 3 (each within the scatter of the next); then compound 2; then compound 4.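

Working from the one readable pair, the position on an aromatic carbon, para to a large group, is not indifferent to this exchange: in this assay the group of 8 heavy atoms in place of the group of 6 heavy atoms gives a 2.6-fold higher number from compound 2 to compound 4 (0.42 log units; beyond the scatter). The step is modest, but it runs towards weaker inhibition, so this larger group, with its 2 double bonds outside aromatic rings, is not tolerated without cost on the core shared by this pair. Both groups count as having no net charge and have the same number of hydrogen-bond donors, so neither of those counts separates the two, and nothing available bears on why the number rises.

The exchange alters the whole group at once, so this pair cannot assign the rise to the end of the chain or to the part joined to the aromatic ring. As far as these compounds go, how this assay would read with a methyl ester or a primary amide in place of the carboxylic acid, or with a longer chain ahead of it, remains open.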